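A second trifluoromethyl on the terminal urea phenyl

The source may report more compounds than this note shows. Statements on the series, on what has been measured and on what is new or still open speak of the compounds shown alone.

Compound 1 `O=C(Nc1cccc(-n2cc(-c3ccncc3)c(-c3ccc(Cl)c(O)c3)n2)c1)Nc1cccc(C(F)(F)F)c1` was tested in a functional assay on SNB-75 cells (Homo sapiens) for inhibition, read by sulforhodamine B assay, with a stated time of 48 h; a higher number here means a weaker inhibitor of growth, a lower number a stronger inhibitor of growth. In this assay compound 1 gave only a limit, > 32500 nM, so its true value is not known. Within the data shown here, its partner compound 2 `O=C(Nc1cccc(-n2cc(-c3ccncc3)c(-c3ccc(Cl)c(O)c3)n2)c1)Nc1ccc(Cl)c(Cl)c1` gave 12200 nM in this assay, and the step of an at least 2.6-fold lower number from compound 1 to compound 2 (0.42 log units; beyond the scatter) is the one measured comparison in the set, though its size rests on (the limit of > 32500 nM in this assay, at which 1 of the 2 values shown sits). Compound 3 `O=C(Nc1cccc(-n2cc(-c3ccncc3)c(-c3ccc(Cl)c(O)c3)n2)c1)Nc1cc(C(F)(F)F)cc(C(F)(F)F)c1` differs from compound 1 by trifluoromethyl in place of hydrogen on an aromatic carbon. Among the measured compounds shown here, no measured step adds a trifluoromethyl in this way; the step from compound 1 to compound 2 only shows that a different halogenated phenyl on the urea nitrogen can bring the number down from the limit. Compound 1 sits at a limit, so the starting point is itself uncertain. Compound 3 is therefore expected to give a number near that limit, with a modest expected step of an at least 1.0-fold lower number from compound 1 to compound 3 (0.03 log units; that floor lies within the scatter), and its value in this assay is estimated at 30000 nM, between 10000 nM and 100000 nM.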

Compound 3, concentration for total growth inhibition: 2180 nM
The estimate for compound 3 lay 14-fold (1.14 log units) above the measured number, outside the stated range (below it).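

At this position on the terminal urea phenyl, meta to a trifluoromethyl group, trifluoromethyl in place of hydrogen gives an at least 14-fold lower number from compound 1 to compound 3 (1.17 log units; beyond the scatter) in this assay. The earlier step had shown a lower number only with a different halogenated phenyl on the urea nitrogen, whereas this one shows that the trifluoromethyl-bearing phenyl can be kept and, with one more trifluoromethyl, still give a large step. Compound 1 stands only at a limit, so the size of this step is a floor: the limit of > 32500 nM in this assay, at which 1 of the 3 values shown sits.

The compounds shown leave open whether another group at this position, such as a methoxy group or an amine, would lower the number as well. They also leave open what a lone trifluoromethyl at this position would give without the first one.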